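The source may report more compounds than this note shows. Statements on the series, on what has been measured and on what is new or still open speak of the compounds shown alone.

In a functional assay with Mus musculus as the target (on this read-out lower numbers stand for stronger inhibition and higher numbers for weaker inhibition), compound 1 `NC1CCCc2onc(O)c21` gives 208000 nM. Compound 2 `C=CCNC1CCCc2onc(O)c21` gives only a limit, > 500000 nM. Compound 3 `CC(=O)OCCNC1CCCc2onc(O)c21` also gives only a limit, > 500000 nM. Compound 2 therefore stands at the limit of > 500000 nM in this assay, at which 2 of the 3 values shown sit. Compound 4 `CN(C)C1CCCc2onc(O)c21` has not yet been measured, and it differs from compound 2 as follows: dimethylamino in place of allylamino on a saturated ring carbon. In words, dimethylamino sits in place of allylamino on a saturated ring carbon. The closest measured change is on the amine nitrogen, an at least 2.4-fold higher number from compound 1 to compound 2 (0.38 log units; beyond the scatter), which is at least modest. The other measured change, a step that the two limits leave unreadable from compound 2 to compound 3, cannot be sized. In this assay the expected step is a number no higher from compound 2 to compound 4 (the limit leaves the size open), so no change beyond the scatter is expected. For compound 4 the estimated value is 500000 nM, with an expected range from 200000 nM to 1200000 nM.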

Compound 4, half-maximal inhibitory concentration: > 500000 nM
Compound 4: a limit, no number; the forecaster's own chance of this, stated with the estimate: 65%; the middle value sits exactly at the limit.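

Dimethylamino in place of amino gives an at least 2.4-fold higher number from compound 1 to compound 4 (0.38 log units; beyond the scatter), so this ring position also loses out with a substituent that has no hydrogen-bond donor, unlike the allylamino of compound 2. Compound 4 gives > 500000 nM, which is a limit. Among the compounds shown, only compound 1, with the free amino group, gives a number, and the substituted amines all stop at the same limit: the limit of > 500000 nM in this assay, at which 3 of the 4 values shown sit.

The steps between those limits cannot be read, so the substituted amines cannot be ranked. As far as these compounds go, whether methylamino or a carboxylic acid at this position would give a readable number remains open.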